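The compounds below may be only part of what the source reports. "The series", "measured", "known", "first", "only" and "open" are said of these compounds alone.

Going by the values given here, in a functional assay on DU-145 cells (Homo sapiens) for inhibition, read by trypan blue exclusion, with a stated time of 96 h (a higher number here means a weaker inhibitor of growth, a lower number a stronger inhibitor of growth), compound 2 `Cc1ccc(CS/C(=C/c2c[nH]c3ccc(Br)cc23)C(=O)c2ccc(Cl)cc2)cc1` gives 1000 nM, the lower of the two numbers so far, and compound 1 `Cc1ccc(CS/C(=C/c2ccc(O)cc2)C(=O)c2ccc(Cl)cc2)cc1` gives 10000 nM. Among the compounds with values here, the one measured step, a 10-fold lower number from compound 1 to compound 2 (1.00 log units; beyond the scatter), put 5-bromo-1H-indol-3-yl in place of 4-hydroxyphenyl. Compound 3 `CSc1ccc(/C=C(/SCc2ccc(C)cc2)C(=O)c2ccc(Cl)cc2)cc1` changes the same place: 4-(methylsulfanyl)phenyl in place of 5-bromo-1H-indol-3-yl on a double-bonded chain carbon bound to a double-bonded chain carbon. This brings back a phenyl group, as in compound 1, so part of that single step is expected to reverse, though one step is thin evidence. The expected change in this assay is a 3.0-fold higher number from compound 2 to compound 3 (0.48 log units; beyond the scatter), towards a higher number. For compound 3 the estimate is 3000 nM, with an expected range of 700 nM to 12000 nM.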

Compound 3, concentration for 50% growth inhibition: 25000 nM
The estimate for compound 3 lay 8.3-fold (0.92 log units) below the measured number; measured number outside the range, above it.
By their numbers in this assay, from the lowest: compound 2; then compound 1; then compound 3.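

Replacing 5-bromo-1H-indol-3-yl with a substituted phenyl group does more than undo the earlier gain in this assay: the change gives a 25-fold higher number from compound 2 to compound 3 (1.40 log units; beyond the scatter) and takes the number past that of compound 1. The two phenyl compounds also differ from each other, as methylsulfanyl in place of hydroxy gives a 2.5-fold higher number from compound 1 to compound 3 (0.40 log units; beyond the scatter), so the group carried on the phenyl ring matters too. No available evidence explains either step.

On these data alone, whether the low number of compound 2 belongs to the indole rings or to the bromine stays open. So does how a phenyl group carrying an amine or a carboxylic acid would compare at this place.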